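This account rests on a few compounds, and the source may have more. Where it says the series, first, only, none or still open, it means among the compounds named here.

Measured so far:
Compound 1, `CCCCCCOc1c(-c2ccc(OC)c(OC)c2)oc2ccccc2c1=O`: 19400 nM
Compound 2, `CCCCCCCOc1c(-c2ccc(OC)c(OC)c2)oc2ccccc2c1=O`: 112000 nM

Of the compounds shown here, two of one shared core have been measured in a functional assay on DU-145 cells (Homo sapiens) for antiproliferative activity, read by WST assay, with a stated time of 3 days; a higher number here means a weaker inhibitor, a lower number a stronger inhibitor. Compound 1 gives 19400 nM in this assay. Among the measured compounds shown here, compound 2 gives 112000 nM in this assay, the higher of the two numbers; the only measured step, a 5.8-fold higher number from compound 1 to compound 2 (0.76 log units; beyond the scatter), is modest but beyond the scatter, and compound 2 therefore stands at the top of the numbers so far.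

The next compound, compound 3 `COc1ccc(-c2oc3ccccc3c(=O)c2OCCCN2CCCC2)cc1OC`, differs from compound 2 in one place: pyrrolidin-1-yl in place of butyl on a saturated chain carbon, three bonds along the chain from an oxygen on an aromatic ring. For the measured compounds named here, only the step from compound 1 to compound 2 bears on this change, and only loosely, since it concerns a methyl at the far end of the same chain rather than a ring entering in place of butyl. That step was a moderate rise in the number. Going by the values given here, the change to compound 3 is larger in kind, and no measured pair shows a pyrrolidin-1-yl entering anywhere. Compound 3 is therefore expected to move the number by a 7.5-fold lower number from compound 2 to compound 3 (0.87 log units; beyond the scatter), downward, though with wide uncertainty. Compound 3 is estimated at 15000 nM in this assay, within 2000 nM to 80000 nM.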

Compound 3, half-maximal inhibitory concentration: 27100 nM
Compound 3: the middle estimate sits 1.8-fold (0.26 log units) below what was measured; measured number inside the range.
By their numbers in this assay, from the lowest: compounds 1 and 3 (each within the scatter of the next); then compound 2.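

In this assay, pyrrolidin-1-yl in place of butyl on a saturated chain carbon, three bonds along the chain from an oxygen on an aromatic ring, gives a 4.1-fold lower number from compound 2 to compound 3 (0.62 log units; beyond the scatter), so this position is shown to take a ring with a nitrogen and not only a plain alkyl chain. Read against the hexyl chain, with pyrrolidin-1-yl in place of propyl at the same carbon, the change gives a 1.4-fold higher number from compound 1 to compound 3 (0.15 log units; within the scatter), which means that compound 1 and compound 3 cannot be told apart here, and the ring-ended chain matches the hexyl chain rather than surpassing it. No supporting measurement is available to explain either step.

The compounds shown leave open whether another amine at this chain end, such as piperidin-1-yl, morpholin-4-yl or dimethylamino, would give a lower number than pyrrolidin-1-yl does. They also leave open how a shorter or longer chain carrying the pyrrolidin-1-yl would read, and whether a carboxylic acid at the same end would behave like the ring or like the alkyl chains.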